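Swapping the Amine Ring of a Thioamide Series

The source may hold more compounds than are shown below. What is called first, only, known or untested is meant among the compounds shown, and "the series" means these compounds.

The account starts from compound 1 `CO[C@@H]1C[C@@H](C(=S)N2CCC(N3CCCC3)CC2)N(C(=O)NCc2ccc(C(=O)N3CCCCc4sccc43)cc2Cl)C1`, which was measured in an assay on isolated protein with Vasopressin V2 receptor (Homo sapiens) as the target; a higher number here means that more compound is needed for the effect, a lower number that less compound is needed. There compound 1 gives 100 nM. Among the measured compounds shown here, its only measured companion is compound 2 `CO[C@@H]1C[C@@H](C(=O)N2CCC(N3CCCC3)CC2)N(C(=O)NCc2ccc(C(=O)N3CCCCc4sccc43)cc2Cl)C1`, a close analogue; in this assay compound 2 gives 1100 nM. For the measured compounds named here, of the two numbers, the one for compound 1 is the lower, and the gap to compound 2 lies beyond the usual scatter of this assay, so compound 1 stands as the more potent of the pair.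

The unmeasured compound 3 `CO[C@@H]1C[C@@H](C(=S)N2CCCN(C)CC2)N(C(=O)NCc2ccc(C(=O)N3CCCCc4sccc43)cc2Cl)C1` differs from compound 1 in one place: 4-methyl-1,4-diazepan-1-yl in place of 4-(pyrrolidin-1-yl)piperidin-1-yl on a thiocarbonyl carbon. Going by the values given here, no measured pair in this set shows the effect of such a change, so any expectation rests on compound 1 alone. Because compound 1 gives 100 nM, a moderate loss is expected for compound 3, with the step of a 2.5-fold higher number from compound 1 to compound 3 (0.40 log units; beyond the scatter) estimated to lie somewhat outside the scatter in the direction of a higher number. Compound 3 is therefore estimated at 250 nM, within a range from 80 nM to 800 nM.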

Compound 3, half-maximal effective concentration: 230 nM
The estimate for compound 3 lay 1.1-fold (0.04 log units) above the measured number, and the stated range covers the measured number.
By their numbers in this assay, from the lowest: compound 1; then compound 3; then compound 2.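

On a thiocarbonyl carbon, 4-methyl-1,4-diazepan-1-yl in place of 4-(pyrrolidin-1-yl)piperidin-1-yl gives in this assay a 2.3-fold higher number from compound 1 to compound 3 (0.36 log units; beyond the scatter) and so counts as a modest loss, small enough that this place is shown not to depend on the one amine group of compound 1. The group that enters differs clearly from the one that leaves, with one seven-membered ring and 8 heavy atoms against a five-membered and a six-membered ring and 11 heavy atoms, yet compound 3 keeps a number much closer to that of compound 1 than to that of compound 2, even though the two differ in more than one place. Nothing available explains the size or the direction of this step.

On these data alone, what remains open is how a morpholine, a piperazine or an open-chain dimethylamino group would fare on the same thiocarbonyl carbon. Also open, as far as these compounds go, is whether the exchange of amine rings would give a step of like size on the carbonyl carbon of compound 2.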